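Amide aryl swap on the thiazolopyridine-free shared core series

A few compounds are considered here, and "the series" means these few. Any claim that something is new, unique, unknown or untested is made for them only; others in the source may bear on it.

Measured so far:
compound 1, `Nc1n[nH]c2cc(-c3cn([C@@H]4CN[C@H](C(=O)Nc5ccc(Br)cc5)C4)nn3)ccc12`: 26.8%
compound 2, `Nc1nc2ccc(-c3cn([C@@H]4CN[C@H](C(=O)Nc5ccc(Cl)cc5Cl)C4)nn3)nc2s1`: 42.2%

In a functional assay on K562/Adr cells (Homo sapiens) for inhibition, read by MTT assay, with a stated time of 48 h, tested at 30 uM (a lower number here means less inhibition, a higher number more inhibition at the concentration tested (going by the name of the read-out)), compound 2 gives 42.2%, the higher of the two numbers recorded; compound 1, which carries a different core, gives 26.8% in this assay, a gap beyond the usual scatter. Compound 3, `Nc1nc2ccc(-c3cn([C@@H]4CN[C@H](C(=O)Nc5ccc(Br)cc5)C4)nn3)nc2s1`, keeps the core of compound 2 and changes only the amide aryl group: 4-bromophenyl in place of 2,4-dichlorophenyl on an amide-type nitrogen. Among the compounds with values here, compound 1 already carries the 4-bromophenyl amide, but on another core, so no single step between measured compounds isolates this change. Within the data shown here, the 4-bromophenyl partner has so far appeared only with the lower number, which is the sole guide. A modest fall is expected, a number 8.2 percentage points lower from compound 2 to compound 3 (within the scatter), though not clearly beyond the scatter. Compound 3 is estimated at 34%, with a range from 18% to 50%.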

Compound 3, a percentage reported as inhibition, at one concentration (the size of the read-out at that concentration, not a potency): 35.9%
Compound 3: middle estimate off by 1.9 percentage points, on the low side; measured number inside the range.
By their numbers in this assay, from the lowest: compounds 1, 3 and 2 (each within the scatter of the next, the first and the last beyond it).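

In this assay the exchange of 2,4-dichlorophenyl for 4-bromophenyl on the amide-type nitrogen, with the core held fixed, gives a number 6.3 percentage points lower from compound 2 to compound 3 (within the scatter) and so does not separate these two aryl groups at this single concentration. With the 4-bromophenyl amide held fixed, the exchange of the core gives a number 9.1 percentage points higher from compound 1 to compound 3 (within the scatter) and is likewise not resolved by this read-out. No measurement at hand explains either step.

Still open, as far as these compounds go, is whether this amide position responds at all to a group other than a halogen-bearing phenyl, such as a phenyl carrying a carboxylic acid or an aminomethyl group, or a saturated cyclohexyl group. These single-concentration percentages also leave potency unknown.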